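Adding fluoro to the 4-methoxyphenyl of compound 3

The source may report more compounds than this note shows. Statements on the series, on what has been measured and on what is new or still open speak of the compounds shown alone.

Compound 1 `COc1cc(-c2ccnc3cc(-c4ccc(Cl)cc4)nn23)cc(OC)c1OC` gives 3070 nM in a functional assay on A549 cells (Homo sapiens) for inhibition, read by CCK-8 assay, with a stated time of 48 h; on this read-out lower numbers stand for stronger inhibition and higher numbers for weaker inhibition
Compound 2 `COc1cc(-c2ccnc3cc(-c4cccc(C)c4)nn23)cc(OC)c1OC` gives 5730 nM in this assay
Compound 3 `COc1ccc(-c2cc3nccc(-c4cc(OC)c(OC)c(OC)c4)n3n2)cc1` gives 376 nM in this assay

Compound 3 at 376 nM stands lowest of the three, and its gaps to both others lie beyond the scatter. Compound 4 `COc1ccc(-c2cc3nccc(-c4cc(OC)c(OC)c(OC)c4)n3n2)cc1F` differs from it by fluoro in place of hydrogen on an aromatic carbon, ortho to a methoxy group (fluoro in place of hydrogen on an aromatic carbon). Among the measured compounds shown here, the steps that bear on this change the same ring: one was modest (an 8.2-fold lower number from compound 1 to compound 3 (0.91 log units; beyond the scatter)) and one large (a 15-fold lower number from compound 2 to compound 3 (1.18 log units; beyond the scatter)), while another stayed within the scatter (a 1.9-fold higher number from compound 1 to compound 2 (0.27 log units; within the scatter)). For the measured compounds named here, none of them tests fluoro, so they show only that this ring can matter. The expected step is small and upward, not beyond the scatter (a 1.4-fold higher number from compound 3 to compound 4 (0.14 log units; within the scatter)). For compound 4 the estimated value is 520 nM (range 170 nM to 1600 nM).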

Compound 4, half-maximal inhibitory concentration: 545 nM
Estimate against measurement, compound 4: 1.0-fold (0.02 log units) below; measured number inside the range.
By their numbers in this assay, from the lowest: compounds 3 and 4 (each within the scatter of the next); then compounds 1 and 2 (each within the scatter of the next).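

In this assay, adding fluoro ortho to a methoxy group leaves the number within the scatter (a 1.4-fold higher number from compound 3 to compound 4 (0.16 log units; within the scatter)), so this position accepts the change. The 3-fluoro-4-methoxyphenyl group also keeps the clear gap to the other two compounds, with an 11-fold lower number from compound 2 to compound 4 (1.02 log units; beyond the scatter) and a 5.6-fold lower number from compound 1 to compound 4 (0.75 log units; beyond the scatter). Nothing available explains why this position accepts fluoro. The compounds shown leave open whether chloro, methyl or an amine at this place would fare as fluoro does, and whether the methoxy group is still needed once fluoro is present.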